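The source may report more compounds than this note shows. Statements on the series, on what has been measured and on what is new or still open speak of the compounds shown alone.

Series notes. Of the compounds shown here, three on the shared core have been measured in a functional assay on HEK293 cells for agonist activity at G-protein coupled receptor 39 (Mus musculus), read by inositol phosphate accumulation; a higher number here means that more compound is needed for the effect, a lower number that less compound is needed. Compound 1 `CNc1nc(NCc2ccc(S(C)(=O)=O)cc2)cc(-c2ccccn2)n1` gives 185 nM in this assay. Compound 2 `COCCNc1nc(NCC2CC2)cc(-c2ccccn2)n1` gives 10000 nM in this assay. Compound 3 `CNc1nc(NCC2CCCCC2)cc(-c2ccccn2)n1` gives 10 nM in this assay. Compound 1 thus stands second highest of the three numbers: compound 3 lies nearest, with a lower number beyond the scatter, and compound 2 lies furthest, with a higher number beyond the scatter. For the measured compounds named here, no two of the measured compounds differ in a single place, so no measured step is available to anchor the next change.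

Compound 4 `CNc1nc(NCc2ccc(NC(C)=O)cc2)cc(-c2ccccn2)n1` is not yet measured. It differs from compound 1 in one place: acetamido in place of methylsulfonyl on an aromatic carbon. Nothing among the three measured compounds shows what such a swap does in this assay. The change is expected to give at most a modest shift toward a higher number, possibly within the scatter; the estimated step is a 1.4-fold higher number from compound 1 to compound 4 (0.13 log units; within the scatter). Compound 4 is expected to give 250 nM in this assay, with a range from 60 nM to 1000 nM.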

Compound 4, half-maximal effective concentration: 2 nM
Estimate against measurement, compound 4: 130-fold (2.10 log units) above, and the stated range ends above it.
By their numbers in this assay, from the lowest: compound 4; then compound 3; then compound 1; then compound 2.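

In this assay, for the compounds shown here, acetamido in place of methylsulfonyl on this aromatic carbon, para to a large group, gives a 93-fold lower number from compound 1 to compound 4 (1.97 log units; beyond the scatter) and provides the first single-place step. The position is therefore highly sensitive to which group it carries, even though both groups have the same heavy-atom count, no ring and no net charge, so that count alone does not set the number here. The entering group has a hydrogen-bond donor that the leaving group lacks, but no measurement available here explains the shift.

The compounds shown leave open whether the step depends on the amide hydrogen, the carbonyl or the whole acetamido group. A primary amine, a carboxylic acid or a longer acyl chain on the same carbon would help separate these possibilities.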